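The source may hold more compounds than are shown below. What is called first, only, known or untested is meant among the compounds shown, and "the series" means these compounds.

Measured in a functional assay on ECa-109 cells for inhibition, with ECa-109 cell line (Homo sapiens) as the target, read by sulforhodamine B assay; a higher number here means a weaker inhibitor, a lower number a stronger inhibitor:
- Compound 1 `Cc1ccc(NC2=CC(=O)c3c(nc4n3[C@H]3OC[C@@H](O)[C@H]3OC4)C2=O)cc1C`: 4090 nM
- Compound 2 `COc1ccccc1NC1=CC(=O)c2c(nc3n2[C@H]2OC[C@@H](O)[C@H]2OC3)C1=O`: > 4000 nM, a limit
- Compound 3 `O=C1C(NC2CCCCC2)=CC(=O)c2c1nc1n2[C@H]2OC[C@@H](O)[C@H]2OC1`: > 16000 nM, a limit

The entry of > 16000 nM for compound 3 is a limit and not a number. Among the compounds with values here, its one readable comparison is an at least 3.9-fold higher number from compound 1 to compound 3 (0.59 log units; beyond the scatter). The other two comparisons give no size: a step that the limit leaves unreadable from compound 1 to compound 2, and a step that the two limits leave unreadable from compound 2 to compound 3.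

Compound 4 `O=C1C(Nc2cccc(Cl)c2)=CC(=O)c2c1nc1n2[C@H]2OC[C@@H](O)[C@H]2OC1` has 3-chlorophenyl in place of cyclohexyl on an amine nitrogen. Compound 1 bears 3,4-dimethylphenyl at that same nitrogen, so the closest guide is an at least 3.9-fold higher number from compound 1 to compound 3 (0.59 log units; beyond the scatter), read in reverse. This single pair supports an expected move to a lower number in this assay, of modest size. The expected step is an at least 4.5-fold lower number from compound 3 to compound 4 (0.66 log units; beyond the scatter), though its true size remains uncertain while compound 3 has only a limit. Compound 4 is estimated at 3500 nM, with an expected range of 1000 nM to 12000 nM.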

Compound 4, half-maximal inhibitory concentration: 3080 nM
Beside the measured number, compound 4's estimate is 1.1-fold (0.06 log units) above it, within the range that was stated.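

In this assay, 3-chlorophenyl in place of cyclohexyl on the amine nitrogen gives an at least 5.1-fold lower number from compound 3 to compound 4 (0.71 log units; beyond the scatter), so a second aromatic group with a measured value now stands against the cyclohexyl entry, which is a limit: the limit of > 16000 nM in this assay, at which 1 of the 4 values shown sits. A chlorine-bearing phenyl and a dimethyl-bearing phenyl cannot be told apart at this nitrogen, with a 1.3-fold lower number from compound 1 to compound 4 (0.12 log units; within the scatter). Compound 2 has only a limit, and an at least 1.2-fold lower number from compound 2 to compound 4 (0.11 log units; that floor lies within the scatter) sets no order between the 2-methoxyphenyl and 3-chlorophenyl groups: the limit of > 4000 nM in this assay, at which 1 of the 4 values shown sits.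

The compounds shown leave open how an unsubstituted phenyl would compare with these substituted rings. They also leave open whether an amine or a carboxylic acid on the ring, or a longer chain in place of it, would move the number beyond the scatter.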